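The source may report more compounds than this note shows. Statements on the series, on what has been measured and on what is new or still open speak of the compounds shown alone.

Measured compounds:
- Compound 1 `Cc1ccc(CSc2nc3nc(C)cc(Nc4cc(-c5ccccc5)[nH]n4)n3n2)cc1`: 36200 nM
- Compound 2 `Cc1cc(Nc2cc(-c3ccccc3)[nH]n2)n2nc(SCc3csc4ccccc34)nc2n1`: 29200 nM
- Compound 3 `C=CCSc1nc2nc(C)cc(Nc3cc(-c4ccccc4)[nH]n3)n2n1`: a limit, > 50000 nM

In an ADME assay on GES1 cells (Homo sapiens) for inhibition, read by MTT assay, with a stated time of 72 h (a higher number here means a weaker inhibitor, a lower number a stronger inhibitor), compound 1 gives 36200 nM, the highest of the two numbers given; compound 2 gives 29200 nM, and a 1.2-fold lower number from compound 1 to compound 2 (0.09 log units; within the scatter). For compound 3 only the assay limit > 50000 nM is reported. Compound 4 `C#CCSc1nc2nc(C)cc(Nc3cc(-c4ccccc4)[nH]n3)n2n1` differs from compound 1 as follows: ethynyl in place of 4-methylphenyl on a saturated chain carbon bound to a sulfur. Among the compounds with values here, the steps that bear on this change are an at least 1.3-fold higher number from compound 1 to compound 3 (0.14 log units; that floor lies within the scatter) and an at least 1.7-fold higher number from compound 2 to compound 3 (0.23 log units; that floor lies within the scatter), both floors set by the limit of > 50000 nM in this assay, at which 1 of the 3 values shown sits, where vinyl replaced the larger groups on the same saturated chain carbon bound to a sulfur. Ethynyl is the smallest entering group among these, so a number at or beyond the same limit is expected, with a 1.5-fold higher number from compound 1 to compound 4 (0.18 log units; within the scatter). Compound 4 is therefore estimated at 55000 nM, in the range 25000 nM to 120000 nM.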

Compound 4, half-maximal inhibitory concentration: 45700 nM
Estimate against measurement, compound 4: 1.2-fold (0.08 log units) above; the measured number falls inside the stated range.
By their numbers in this assay, from the lowest: compounds 2, 1 and 4 (each within the scatter of the next). At a limit, above all of these: compound 3.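

Among the groups without a ring on this saturated chain carbon bound to a sulfur, compound 4 gives a number rather than a limit in this assay. Ethynyl in place of 4-methylphenyl gives a 1.3-fold higher number from compound 1 to compound 4 (0.10 log units; within the scatter), and ethynyl in place of 1-benzothiophen-3-yl gives a 1.6-fold higher number from compound 2 to compound 4 (0.19 log units; within the scatter). Compound 3 is held at a limit, so ethynyl in place of vinyl can be read only as a floor, with an at least 1.0-fold lower number from compound 3 to compound 4 (0.03 log units; that floor lies within the scatter): the limit of > 50000 nM in this assay, at which 1 of the 4 values shown sits.

Within the data shown here, no step at this position yet lies beyond the scatter. From the compounds shown here alone, whether an amine, a carboxylic acid or a longer chain in this place would give one remains open.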